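From ethyl to 4-methylphenyl on a sulfonyl sulfur

A few compounds are considered here, and "the series" means these few. Any claim that something is new, unique, unknown or untested is made for them only; others in the source may bear on it.

Compound 1 `C1CCCC2(CC1)OOC1(CCCCCC1)OO2`: > 100 ug/mL
Compound 2 `CCS(=O)(=O)N1CCC2(CC1)OOC1(CCCC1)OO2`: > 100 ug/mL
Compound 3 `CCS(=O)(=O)N1CCC2(CC1)OOC1(CCCCC1)OO2`: > 100 ug/mL

All three entries come from a functional assay on Huh-7 cells (Homo sapiens) for cytotoxicity, read by MTT assay, with a stated time of 72 h (a higher number here means that more compound is tolerated, a lower number that less compound is tolerated), and none of them is an exact number. The whole set is summed up as the limit of > 100 ug/mL in this assay, at which 3 of the 3 values shown sit. Compound 2 gives > 100 ug/mL, which is a limit of the assay and not a number. Compound 2 therefore has no exact place in a ranking, and the same holds for compound 1 and compound 3.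

The next compound is compound 4 `Cc1ccc(S(=O)(=O)N2CCC3(CC2)OOC2(CCCC2)OO3)cc1`. It keeps the rest of compound 2 and carries 4-methylphenyl in place of ethyl on a sulfonyl sulfur. For the measured compounds named here, no measured pair here shows what a change at this place does, so any expectation is tentative. It rests on compound 2, whose entry is > 100 ug/mL. No step beyond the scatter is expected in this assay, although if a real step does appear, a lower number is the more likely direction. The expected step is a number no higher from compound 2 to compound 4 (the limit leaves the size open). For compound 4 the estimated value is 100 ug/mL, with an expected range from 45 ug/mL to 200 ug/mL. A report of only a limit would be no surprise.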

Compound 4, half-maximal cytotoxic concentration: > 100 ug/mL
Compound 4 ended at the assay's limit (the forecaster's own chance of this, stated with the estimate: 65%); the middle value sits exactly at the limit.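

Putting 4-methylphenyl in place of ethyl gives no step that can be read, since compound 2 and compound 4 each report only a limit and not a number: the limit of > 100 ug/mL in this assay, at which 4 of the 4 values shown sit.

The compounds shown leave open how much of each compound is really tolerated, and whether this swap changes that at all.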